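The source may hold more compounds than are shown below. What is called first, only, known or untested is meant among the compounds shown, and "the series" means these compounds.

Working notes on the series. In an in vitro assay on SH-SY5Y cells for displacement of a labelled ligand from Neuronal acetylcholine receptor; alpha3/beta4 (Homo sapiens) (on this read-out lower numbers stand for stronger inhibition and higher numbers for weaker inhibition), compound 3 `CC(C)Oc1cncc(C2=CC3CNCC(C2)C3)c1` gives 4.8 nM, the lowest number among the three measured compounds. Compound 2 `CN1CC2C=C(c3cncc(Cl)c3)CC(C2)C1` gives 1830 nM and compound 1 `CN1CC2C=C(c3cncc(C#N)c3)CC(C2)C1` gives 4500 nM; both stand far above compound 3. Within the data shown here, the only measured step, a 2.5-fold lower number from compound 1 to compound 2 (0.39 log units; beyond the scatter), concerns the substituent on the aromatic ring and leaves the amine nitrogen untouched.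

Compound 4 `CC(C)Oc1cncc(C2=CC3CC(C2)CN(C)C3)c1` differs from compound 3 by methyl in place of hydrogen on an amine nitrogen in a ring. Among the measured compounds shown here, no measured pair isolates this change. Compounds 1 and 2 do carry the methyl on that nitrogen, but they also bear a different aromatic substituent than compound 3, so their gap to compound 3 cannot be split between the two differences. The expectation for compound 4 therefore rests on that gap only loosely. The estimated step is a 3.1-fold higher number from compound 3 to compound 4 (0.49 log units; beyond the scatter), a move toward a higher number in this assay, carrying wide uncertainty. Compound 4 is estimated at 15 nM, with a range from 4 nM to 80 nM.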

Compound 4, inhibition constant: 1730 nM
Compound 4: middle estimate off by 120-fold (2.06 log units), on the low side; measured number above the stated range.
By their numbers in this assay, from the lowest: compound 3; then compounds 4 and 2 (each within the scatter of the next); then compound 1.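

In this assay, methyl in place of hydrogen on the amine nitrogen in a ring is now seen as a single change, and it gives a 360-fold higher number from compound 3 to compound 4 (2.56 log units; beyond the scatter) as a large loss at this position. With that methyl present, the aromatic substituent counts for far less: isopropoxy in place of chloro gives a 1.1-fold lower number from compound 2 to compound 4 (0.02 log units; within the scatter) and isopropoxy in place of cyano gives a 2.6-fold lower number from compound 1 to compound 4 (0.42 log units; beyond the scatter) as a modest step, so the low number of compound 3 goes with the hydrogen on that nitrogen and not with isopropoxy alone. Nothing at hand gives a reason for this step.

The compounds shown leave open whether an ethyl or a benzyl group on that nitrogen would behave as methyl does. They also leave open how chloro or cyano would read with hydrogen on that nitrogen.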